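Extending the methyl end of compound 1 to propyl

A few compounds are considered here, and "the series" means these few. Any claim that something is new, unique, unknown or untested is made for them only; others in the source may bear on it.

In a functional assay on HT-29 cells (Homo sapiens) for antiproliferative activity, read by sulforhodamine B assay, with a stated time of 48 h (a higher number here means a weaker inhibitor, a lower number a stronger inhibitor), compound 1 `COc1ccccc1OS(=O)(=O)c1ccc(N2CCN(C)C2=O)cc1` gives 26000 nM, the highest number of the three measured, with compound 3 `CN1CCN(c2ccc(S(=O)(=O)Oc3ccc(Cl)cc3)cc2)C1=O` at 12000 nM and compound 2 `CN1CCN(c2ccc(S(=O)(=O)Oc3cccc(I)c3)cc2)C1=O` at 590 nM. Compound 4 `CCCN1CCN(c2ccc(S(=O)(=O)Oc3ccccc3OC)cc2)C1=O` keeps the group on the oxygen of compound 1 and has ethyl in place of hydrogen on a saturated chain carbon bound to an amide-type nitrogen in a ring. The measured steps, a 44-fold lower number from compound 1 to compound 2 (1.64 log units; beyond the scatter) and a 2.2-fold lower number from compound 1 to compound 3 (0.34 log units; beyond the scatter), all change the group on the oxygen. None tests this place, so they give only a loose guide to size and none to direction. The expected step is a 2.2-fold lower number from compound 1 to compound 4 (0.34 log units; beyond the scatter), a modest one held with low confidence. Compound 4 is estimated at 12000 nM, with an expected range of 3000 nM to 40000 nM.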

Compound 4, half-maximal inhibitory concentration: > 100000 nM
Compound 4 gave a limit, no number (the forecaster's own chance of this, stated with the estimate: 5%); middle value at least 8.3-fold (0.92 log units) away from the limit.
By their numbers in this assay, from the lowest: compound 2; then compound 3; then compound 1. At a limit, above all of these: compound 4.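

The earlier compounds shown here changed only the group on the oxygen, so they said nothing about direction at this saturated chain carbon bound to an amide-type nitrogen in a ring. Going from methyl to propyl here in this assay gives an at least 3.8-fold higher number from compound 1 to compound 4 (0.58 log units; beyond the scatter) and so sets a direction, upward, opposite to the steps from compound 1 to compound 2 and to compound 3. The value of compound 4 is a limit, not a number: the limit of > 100000 nM in this assay, at which 1 of the 4 values shown sits.

As far as these compounds go, how far the number rises therefore stays open. Also open, from the compounds shown here alone, are whether an ethyl chain, or a propyl chain ending in an amine, behaves the same way, and whether propyl has this effect with the 3-iodophenyl group of compound 2.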